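Fluoro Gives Way to Bromo

The source may hold more compounds than are shown below. What is called first, only, known or untested is meant among the compounds shown, and "the series" means these compounds.

Measured in a physicochemical assay for lipophilicity, at pH 7.4; a lower number here means a more polar compound, a higher number a more lipophilic compound:
Compound 1 `Cc1[nH]c2c(Cl)cccc2c(=O)c1Cc1ccccc1`: 2.78
Compound 2 `CCc1c(C)[nH]c2cc(OC)c(F)cc2c1=O`: 1.2

Compound 2, at 1.2, holds the lower of the two numbers, and its gap to compound 1 lies beyond the usual scatter of repeated measurements. The next compound to be measured is compound 3 `CCc1c(C)[nH]c2cc(OC)c(Br)cc2c1=O`, which departs from compound 2 in a single place: bromo in place of fluoro on an aromatic carbon. Put simply, it has bromo in place of fluoro on an aromatic carbon, ortho to a methoxy group.

For the measured compounds named here, no two measured compounds here differ in only one place, so the data offer no direct measure of this swap in this assay. The expectation therefore rests on the structural change alone. A rise in the number, beyond the scatter, is expected. The estimated move is a number 0.70 log units higher from compound 2 to compound 3 (beyond the scatter). That would be expected to leave the new compound short of compound 1. For compound 3 the estimated value is 1.9, with an expected range of 1.5 to 2.3.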

Compound 3, distribution coefficient: 1.7
Compound 3: the middle estimate sits 0.20 log units above what was measured; the measured number falls inside the stated range.
By their numbers in this assay, from the lowest: compound 2; then compound 3; then compound 1.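

For the compounds shown here, this is the first direct measure of a change in one place at this position: in this assay, bromo in place of fluoro on the aromatic carbon ortho to a methoxy group gives a number 0.50 log units higher from compound 2 to compound 3 (beyond the scatter), a modest step. Fluoro and bromo each count as 1 heavy atom, with no hydrogen-bond donor or acceptor and no net charge, so those counts do not separate the two compounds, and yet the number moves. The compounds therefore show that this position is not silent in this assay, even for an exchange of one halogen for another, but no measurement shown here bears on why the number moves.

As far as these compounds go, what a nitrile or an amine on this same aromatic carbon would do to the number remains open. So does whether bromo in place of fluoro would give a similar step at another position or on another core, since a single step cannot set a trend.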